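A Halogen Swap Carried onto a Second Core

This account rests on a few compounds, and the source may have more. Where it says the series, first, only, none or still open, it means among the compounds named here.

Four compounds are compared here. Compound 1 `O=C1/C(=C/c2cccc(Cl)c2)Cc2ccccc21` and compound 2 `O=C1/C(=C/c2cccc(Br)c2)Cc2ccccc21` share one core; compound 3 `O=C1/C(=C/c2cccc(Cl)c2)CCCc2ccccc21` and compound 4 `O=C1/C(=C/c2cccc(Br)c2)CCCc2ccccc21` share another. The difference between the two cores is not broken down here.

In a functional assay on P388 cells (Mus musculus) for inhibition (on this read-out higher numbers stand for weaker inhibition and lower numbers for stronger inhibition), compound 1 gives 26300 nM. Compound 2 gives 21000 nM in this assay. Among the measured compounds shown here, the only change from compound 1 to compound 2 is this: bromo in place of chloro on an aromatic carbon. The step it made was a 1.3-fold lower number from compound 1 to compound 2 (0.10 log units; within the scatter), so the two values cannot be told apart.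

Compound 3 gives 8200 nM in this assay, and its value sits below those of compound 1 and compound 2 by more than the scatter, so the second core appears to carry the stronger inhibition among these three.

Compound 4 differs from compound 3 by the same change, made at the same place: bromo in place of chloro on an aromatic carbon. For the measured compounds named here, the one earlier example of this change, measured between compound 1 and compound 2, is a 1.3-fold lower number from compound 1 to compound 2 (0.10 log units; within the scatter), which rests the expectation for compound 4 on a step of about the same size. The step from compound 3 to compound 4 is therefore expected to be a 1.3-fold lower number from compound 3 to compound 4 (0.10 log units; within the scatter). Compound 4 is expected to give about 6500 nM in this assay, with the value estimated to fall between 3300 nM and 13000 nM.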

Compound 4, half-maximal inhibitory concentration: 10500 nM
Beside the measured number, compound 4's estimate is 1.6-fold (0.21 log units) below it; measured number inside the range.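

In this assay the swap of bromo for chloro on the second core gives a 1.3-fold higher number from compound 3 to compound 4 (0.11 log units; within the scatter) and so compound 3 and compound 4 cannot be told apart. Set beside the same swap on the first core, the new step shows no difference that can be trusted: the same change on two cores in this assay, a 1.3-fold lower number (0.10 log units; within the scatter) from compound 1 to compound 2 and a 1.3-fold higher number (0.11 log units; within the scatter) from compound 3 to compound 4, 1.6-fold (0.21 log units) apart, within the scatter of two such steps. On these two cores, then, the swap carries over in a modest sense, since it leaves the read-out within the usual scatter of repeated measurements both times, but two pairs are too few to make a rule for the series, a small real effect could be hidden in that scatter, and nothing here explains the result.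

Chloro and bromo are the only groups shown at this place on the aromatic ring, so it remains open what a fluoro group, a methoxy group, an amine or a carboxylic acid would do there on either core. Also open, from the compounds shown here alone, is whether the agreement between the two steps would hold on a third core or in a different kind of test.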